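Furan, pyrrolinone and lactone ends on a shared terpenoid core

A few compounds are considered here, and "the series" means these few. Any claim that something is new, unique, unknown or untested is made for them only; others in the source may bear on it.

Two compounds share a long, branched chain bearing a five-membered hydroxy-enone lactone at one end and differ at the other end. Compound 1 `CC1=C(O)[C@@H](C/C(C)=C\CC[C@H](C)/C=C/C=C(\C)CCCc2ccoc2)OC1=O` carries a furan there, while compound 2 `CC1=C(O)[C@H](C/C(C)=C\CC[C@H](C)/C=C/C=C(\C)CCCC2=CCN(CCC(C)C)C2=O)OC1=O` carries a pyrrolinone. In a functional assay on SK-MEL-2 cells (Homo sapiens) for cytotoxicity (a lower number here means that less compound is needed, a higher number that more compound is needed for the effect), compound 1 gives 5.6 ug/mL and compound 2 gives 4.1 ug/mL. Compound 2 has the lowest of the two numbers, but its nearest neighbour, compound 1, stands within the scatter, so the two cannot be placed in any order of effect.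

Compound 3 `COC1C=C(CCC/C(C)=C/C=C/[C@@H](C)CC/C=C(/C)C[C@@H]2OC(=O)C(C)=C2O)C(=O)O1` has not been measured. It differs from compound 2 as follows: a group of 8 heavy atoms (5 carbon, 3 oxygen; one five-membered non-aromatic ring with 1 hetero atom) in place of a group of 11 heavy atoms (9 carbon, 1 nitrogen, 1 oxygen; one five-membered non-aromatic ring with 1 hetero atom), on a saturated chain carbon, three bonds along the chain from a double-bonded chain carbon. For the measured compounds named here, no step between measured compounds is available, so the expectation for compound 3 rests only on the two values above, which themselves lie close together. Compound 3 is therefore expected to show a step of a 1.2-fold higher number from compound 2 to compound 3 (0.09 log units; within the scatter) in this assay, not beyond the scatter in either direction. The estimate for compound 3 in this assay is 5 ug/mL, with a range from 2 ug/mL to 12 ug/mL.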

Compound 3, concentration for half-maximal effect: 7.6 ug/mL
Compound 3: the middle estimate sits 1.5-fold (0.18 log units) below what was measured; the measured number falls inside the stated range.
By their numbers in this assay, from the lowest: compounds 2, 1 and 3 (each within the scatter of the next).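

In this assay, the exchange on a saturated chain carbon, three bonds along the chain from a double-bonded chain carbon, gives a 1.9-fold higher number from compound 2 to compound 3 (0.27 log units; within the scatter). For the compounds shown here, this is the first step that can be read at this position: a group of 8 heavy atoms with 3 hydrogen-bond acceptors and no nitrogen takes the place of a group of 11 heavy atoms with 1 nitrogen and 1 hydrogen-bond acceptor, and the two compounds cannot be told apart in this read-out. No measurement of any property of these compounds bears on this result, and the size of the step stays unexplained.

From the compounds shown here alone, it remains open whether a group of another kind at this end of the chain, such as an amine, a carboxylic acid or a longer chain without a ring, would move the number beyond the scatter. Equally open, going by these compounds, is whether the same exchange would read alike in cells other than those of this assay.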